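The source may report more compounds than this note shows. Statements on the series, on what has been measured and on what is new or still open speak of the compounds shown alone.

Three related compounds have numbers in a functional assay on PC-3 cells (Homo sapiens), read by MTT assay, with a stated time of 48 h; on this read-out higher numbers stand for weaker inhibition and lower numbers for stronger inhibition. Compound 1 (`CCn1c(C(=O)NCCN)ccc1C(CC)(CC)c1ccc(OCC(=O)C(C)(C)C)c(C)c1`) gives 480 nM there, compound 2 (`CCN(CC)CCCNC(=O)c1ccc(C(CC)(CC)c2ccc(OCC(O)C(C)(C)C)c(C)c2)n1CC`) gives 2500 nM and compound 3 (`C#CCNC(=O)c1ccc(C(CC)(CC)c2ccc(OCC(O)C(C)(C)C)c(C)c2)n1CC`) gives 16200 nM as the highest number of the three. Compound 3 is thus the weakest inhibitor so far, with its gaps to both other compounds beyond the scatter.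

Compound 4 (`CC[C@@H](C)[C@H](NC(=O)c1ccc(C(CC)(CC)c2ccc(OCC(O)C(C)(C)C)c(C)c2)n1CC)C(=O)O`) departs from compound 3 at the amide-type nitrogen, where 1-carboxy-2-methylbutyl stands in place of propargyl (1-carboxy-2-methylbutyl in place of propargyl on an amide-type nitrogen). Among the measured compounds shown here, one measured step bears on this part of the structure (a 6.5-fold higher number from compound 2 to compound 3 (0.81 log units; beyond the scatter)). It shows that a change in this side chain can move the number beyond the scatter, but it is a modest step and involves a different pair of groups. For the measured compounds named here, no measured compound carries the entering group, so the data give no firm direction. Only a small rise in the number is expected in this assay, with no step beyond the scatter. The estimated step is (a 1.4-fold higher number from compound 3 to compound 4 (0.13 log units; within the scatter)) and stays within that expectation. Compound 4 is expected to read about 22000 nM in this assay, with an estimated range from 7000 nM to 70000 nM for a measurement.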

Compound 4, half-maximal inhibitory concentration: 1900 nM
Estimate against measurement, compound 4: 12-fold (1.06 log units) above; the measured number lies below the stated range.
By their numbers in this assay, from the lowest: compound 1; then compounds 4 and 2 (each within the scatter of the next); then compound 3.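

In this assay, putting 1-carboxy-2-methylbutyl in place of propargyl on the amide-type nitrogen gives an 8.5-fold lower number from compound 3 to compound 4 (0.93 log units; beyond the scatter), the second step at this position seen to lie beyond the scatter and the first to run towards a lower number. Set against the 3-(diethylamino)propyl chain, the same group gives a 1.3-fold lower number from compound 2 to compound 4 (0.12 log units; within the scatter), which lies within the scatter, so two chains with very different end groups, a diethylamino group and a carboxylic acid, read alike here. Among the compounds shown here, the earlier step from the diethylamino chain to propargyl could have suggested that the amine was needed at this position, but compound 4 carries no such amine and shows that it is not, leaving propargyl as the one group of the three that stands apart.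

The compounds shown leave open whether the carboxylic acid, the branched carbon chain or the two defined stereocentres account for the step, which a methyl ester of the acid, an unbranched chain bearing the same acid or the opposite stereoisomer would help to separate. Nothing shown here gives a measured reason for the difference between these groups.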